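A few compounds are considered here, and "the series" means these few. Any claim that something is new, unique, unknown or untested is made for them only; others in the source may bear on it.

Of the compounds shown here, three sharing one core have been measured. Compound 1 `COc1ccc(-c2nc(SCC(=O)c3sc(-c4ccccc4)nc3C)[nH]c(=O)c2C#N)cc1` in a functional assay on U-87MG ATCC cells for antiproliferative activity against U-87 MG (Homo sapiens), read by MTT assay, with a stated time of 48 h, tested at 50 uM (a lower number here means a stronger effect, a higher number a weaker effect of the compound at the concentration tested), gives 52.1%. Compound 2 `COc1ccc(-c2nc(C)c(C(=O)CSc3nc(-c4ccc(OC)cc4)c(C#N)c(=O)[nH]3)s2)cc1`, which carries a methoxy in place of hydrogen on an aromatic carbon, gives 32.6%, and compound 3 `Cc1nc(-c2ccc(Cl)cc2)sc1C(=O)CSc1nc(-c2cccc(Cl)c2)c(C#N)c(=O)[nH]1` gives 52.6%. Among the measured compounds shown here, compound 1 thus stands within the scatter of compound 3 and clearly apart from compound 2, the one step recorded so far being a number 19.5 percentage points lower from compound 1 to compound 2 (beyond the scatter).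

The unmeasured compound 4 `Cc1nc(-c2ccccc2)sc1C(=O)CSc1nc(-c2ccc(Cl)c(Cl)c2)c(C#N)c(=O)[nH]1` differs from compound 1 by 3,4-dichlorophenyl in place of 4-methoxyphenyl on an aromatic carbon. For the measured compounds named here, no measured step bears on this place: the step from compound 1 to compound 2 concerns a methoxy on a different ring, and no step is recorded between compound 1 and compound 3, whose values are simply near each other even though compound 3 carries chlorine rather than methoxy on the ring attached to the core. With nothing pointing either way, the change in compound 4 is expected to give no step beyond the scatter, a number 2.1 percentage points lower from compound 1 to compound 4 (within the scatter). Compound 4 is therefore estimated at 50%, with a range from 30% to 70%.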

Compound 4, a percentage reported as activity, at one concentration (the size of the read-out at that concentration, not a potency): 75.3%
Compound 4: the middle estimate sits 25.3 percentage points below what was measured; the whole stated range lies below it.
By their numbers in this assay, from the lowest: compound 2; then compounds 1 and 3 (each within the scatter of the next); then compound 4.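

In this assay, the group on the aromatic carbon next to the ring nitrogen and ortho to a cyano group proves to matter: putting 3,4-dichlorophenyl in place of 4-methoxyphenyl gives a number 23.2 percentage points higher from compound 1 to compound 4 (beyond the scatter) in this series. Among the compounds shown here, a higher number here means a weaker effect at the concentration tested, so this change weakens the effect, and it is the first step recorded at this position, the earlier step having concerned a methoxy on a different ring. The two groups match in their kind of ring and in their count of heavy atoms, so the step comes with an exchange of substituents on that ring, the methoxy and its hydrogen-bond acceptor leaving and two chlorine atoms entering, and not with a change in the number of heavy atoms.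

The compounds shown do not separate the loss of the methoxy from the arrival of either chlorine, and they leave open how a plain phenyl, an amine or a carboxylic acid would behave at this position. No measurement at hand gives a reason for the step.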